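The source may report more compounds than this note shows. Statements on the series, on what has been measured and on what is new or still open speak of the compounds shown alone.

Compound 1 `COC(=O)c1cc(-c2cccc(NC(=O)c3ccc(/C=C/C(=O)c4ccccc4O)cc3)c2)on1`: "not determined" (no result reported)
Compound 2 `COC(=O)c1cc(-c2cccc(NC(=O)c3ccc(/C=C/C(=O)c4ccccc4C)cc3)c2)on1`: > 25 ug/mL
Compound 3 `COC(=O)c1cc(-c2cccc(NC(=O)c3ccc(/C=C/C(=O)c4ccccc4Cl)cc3)c2)on1`: > 25 ug/mL

The three compounds share one core and differ only in the ring attached to a carbonyl carbon. In an ADME assay on Vero cells (Chlorocebus sabaeus) for cytotoxicity, read by MTT assay, with a stated time of 72 h (a higher number here means that more compound is tolerated, a lower number that less compound is tolerated), compound 1 has "not determined" (no result reported). Compound 2 gives > 25 ug/mL, which is a limit of this assay and not a number. Compound 3 likewise gives > 25 ug/mL, again a limit. Compound 3 therefore stands at the limit of > 25 ug/mL in this assay, at which 2 of the 3 values shown sit, where one other compound sits too. The step that the two limits leave unreadable from compound 2 to compound 3 cannot be read. Compound 4 `COC(=O)c1cc(-c2cccc(NC(=O)c3ccc(/C=C/C(=O)c4cc(OC)c(OC)c(OC)c4)cc3)c2)on1` brings a new change: 3,4,5-trimethoxyphenyl in place of 2-chlorophenyl on a carbonyl carbon. Within the data shown here, no measured step involves a 3,4,5-trimethoxyphenyl group, so nothing shows a direction. Compound 4 is expected to stay near the limit, the estimated step being a step that the limit leaves unreadable from compound 3 to compound 4. Compound 4 is estimated at 30 ug/mL, from 10 ug/mL to 100 ug/mL.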

Compound 4, half-maximal cytotoxic concentration: > 50 ug/mL
Compound 4 was reported as a limit; the forecaster's own chance of this, stated with the estimate: 70%; middle value at least 1.6-fold (0.22 log units) from the limit.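

In this assay compound 4 gives > 50 ug/mL, a limit and not a number. Its steps from compound 2 and compound 3 cannot be read. The compounds shown leave open whether the ring on the carbonyl carbon changes tolerance at all.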